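This account rests on a few compounds, and the source may have more. Where it says the series, first, only, none or still open, it means among the compounds named here.

Measured in a functional assay on HL-60 cells (Homo sapiens) for inhibition, read by MTT assay; on this read-out lower numbers stand for stronger inhibition and higher numbers for weaker inhibition:
Compound 1 `CC1(C)C2CCC1(C)C(OC(=O)/C=C/c1ccc(O)c(O)c1[N+](=O)[O-])C2`: 52900 nM
Compound 2 `O=C(/C=C/c1cc(O)c(O)c([N+](=O)[O-])c1)OCCc1ccccc1`: "not determined" (no result reported)
Compound 3 `O=C(/C=C/c1cc(O)c(O)c(Cl)c1)OCCc1ccccc1`: 7010 nM

Of the two numbers available in this assay, compound 3 holds the lower, well clear of compound 1 at 52900 nM. Compound 4 `O=C(/C=C/c1cc(O)c(O)c(Br)c1)OCCc1ccccc1`, not yet measured, carries bromo in place of chloro on an aromatic carbon. That carbon is ortho to a hydroxy group. Among the measured compounds shown here, no measured pair of compounds shows this exchange, so the expectation rests on compound 3 at 7010 nM and on the small size of the change. Expected is a 1.1-fold lower number from compound 3 to compound 4 (0.03 log units; within the scatter), a step within the scatter, leaning slightly toward a lower number. Compound 4 is estimated at 6500 nM, with an expected range of 2500 nM to 17000 nM.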

Compound 4, half-maximal inhibitory concentration: 8490 nM
Compound 4: the middle estimate sits 1.3-fold (0.12 log units) below what was measured; the range from low to high includes it.
By their numbers in this assay, from the lowest: compounds 3 and 4 (each within the scatter of the next); then compound 1.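

In this assay, bromo in place of chloro on this aromatic carbon, ortho to a hydroxy group, gives a step (a 1.2-fold higher number from compound 3 to compound 4 (0.08 log units; within the scatter)) that does not separate the two compounds. Among the compounds shown here, this position therefore accepts either halogen with no difference that this assay can resolve, which no earlier pair could show. Nothing at hand explains this result. Going by these compounds, it remains open whether fluoro, methyl or an amine on this carbon would read the same way, and whether a longer chain on the ester oxygen of the shared core would alter the reading.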